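The source may report more compounds than this note shows. Statements on the series, on what has been measured and on what is new or still open speak of the compounds shown alone.

Compound 3, with the structure `CC(O)(C(=O)Nc1ccc(S(=O)(=O)c2ccc([N+](=O)[O-])cc2)cc1)C(F)(F)F`, stands at the edge of what can be seen here. In a functional assay (Cavia porcellus) with sulfonylurea receptors; K-ATP channels (Homo sapiens) as the target (on this read-out higher numbers stand for weaker inhibition and lower numbers for stronger inhibition), compound 3 gives > 30000 nM, which is a limit of the assay and not a number. Compound 2, with the structure `COc1ccc(S(=O)(=O)c2ccc(NC(=O)C(C)(O)C(F)(F)F)cc2)cc1`, also reaches only a limit. In this assay compound 2 gives > 30000 nM, again a limit rather than a number. Within the data shown here, the one readable value belongs to compound 1, with the structure `CC(O)(C(=O)Nc1ccc(S(=O)(=O)c2ccccc2C#N)cc1)C(F)(F)F`, which in this assay gives 1100 nM. From there the change to compound 2 brought an at least 27-fold higher number from compound 1 to compound 2 (1.43 log units; beyond the scatter), and the change to compound 3 brought an at least 27-fold higher number from compound 1 to compound 3 (1.43 log units; beyond the scatter), while between compound 2 and compound 3 there is a step that the two limits leave unreadable from compound 2 to compound 3, since both sit at the limit of > 30000 nM in this assay, at which 2 of the 3 values shown sit.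

Compound 4, with the structure `CC(O)(C(=O)Nc1ccc(S(=O)(=O)c2cncs2)cc1)C(F)(F)F`, differs from compound 3 by 1,3-thiazol-5-yl in place of 4-nitrophenyl on a sulfonyl sulfur. Among the measured compounds shown here, no measured step touches a thiazolyl group on the sulfonyl sulfur, so the only guidance is that both replacements of 2-cyanophenyl tried so far pushed the number out of range. The step from compound 3 to compound 4 is therefore expected to be an at least 2.5-fold lower number from compound 3 to compound 4 (0.39 log units; beyond the scatter), with wide uncertainty in either direction. Compound 4 is estimated at 12000 nM, within a range from 2000 nM to 60000 nM.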

Compound 4, half-maximal inhibitory concentration: 7700 nM
Estimate against measurement, compound 4: 1.6-fold (0.19 log units) above; low and high end bracket the measured number.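

Replacing 2-cyanophenyl on the sulfonyl sulfur need not push the read-out off the scale: the 1,3-thiazol-5-yl group of compound 4 gives a readable number in this assay, while the 4-methoxyphenyl and 4-nitrophenyl groups of compound 2 and compound 3 stop at a limit of the assay, which is not a number: the limit of > 30000 nM in this assay, at which 2 of the 4 values shown sit. As far as these compounds go, the ring at this position therefore sets more than a simple all-or-nothing result, with an at least 3.8-fold lower number from compound 3 to compound 4 (0.59 log units; beyond the scatter) and an at least 3.8-fold lower number from compound 2 to compound 4 (0.59 log units; beyond the scatter), and the true size of both steps stays unknown past those bounds. The 2-cyanophenyl group still gives the lowest number of the compounds shown, with a 7.0-fold higher number from compound 1 to compound 4 (0.85 log units; beyond the scatter), so the five-membered ring recovers only part of the inhibition.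

The step between compound 2 and compound 3 cannot be read, so nothing can be said about methoxy against nitro. From the compounds shown here alone, compound 1 and compound 4 differ in both the ring and its substituent, so it stays open whether the nitrile matters by itself, and a plain phenyl, a 2-methoxyphenyl or a 1,3-thiazol-5-yl ring carrying a nitrile on the sulfonyl sulfur would begin to separate those two parts.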